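This account rests on a few compounds, and the source may have more. Where it says the series, first, only, none or still open, it means among the compounds named here.

Measured so far in a functional assay on HCT-116 cells (Homo sapiens), read by MTT assay, with a stated time of 72 h; on this read-out lower numbers stand for stronger inhibition and higher numbers for weaker inhibition:
Compound 1 `CN(C)c1ncnc2c1c(-c1ccsc1)cn2[C@@H]1O[C@H](CO)[C@@H](O)[C@H]1O` gives > 20000 nM, a limit only.
Compound 2 `CN(C)c1ncnc2c1c(-c1ccoc1)cn2[C@@H]1O[C@H](CO)[C@@H](O)[C@H]1O` gives > 20000 nM, a limit only.
Compound 3 `C#Cc1cn([C@@H]2O[C@H](CO)[C@@H](O)[C@H]2O)c2ncnc(N(C)C)c12` gives 290 nM.

Compound 2 therefore stands only at a limit, with no number of its own; the limit of > 20000 nM in this assay, at which 2 of the 3 values shown sit, covers it and compound 1 alike. The measured steps all change the group on the aromatic carbon of the five-membered ring: a step that the two limits leave unreadable from compound 1 to compound 2 is unreadable, while an at least 68-fold lower number from compound 1 to compound 3 (1.83 log units; beyond the scatter) and an at least 68-fold lower number from compound 2 to compound 3 (1.83 log units; beyond the scatter) are large. None of them touches the dimethylamino. Within the data shown here, compound 4 `CSc1ncnc2c1c(-c1ccoc1)cn2[C@@H]1O[C@H](CO)[C@@H](O)[C@H]1O` differs from compound 2 by methylsulfanyl in place of dimethylamino on an aromatic carbon, so no measured step bears on it, and the furan-3-yl of compound 2 stays in place. The expectation for compound 4 is therefore no step beyond the scatter, a step that the limit leaves unreadable from compound 2 to compound 4, most likely again a limit. Compound 4 is estimated at 25000 nM, between 8000 nM and 80000 nM.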

Compound 4, half-maximal inhibitory concentration: 100 nM
Beside the measured number, compound 4's estimate is 250-fold (2.40 log units) above it; the whole stated range lies above it.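

Earlier steps changed only the group on the five-membered ring, leaving the aromatic carbon next to the ring nitrogen untested. With furan-3-yl held in place, methylsulfanyl in place of dimethylamino gives an at least 200-fold lower number from compound 2 to compound 4 (2.30 log units; beyond the scatter) in this assay, so this position also governs the read-out, and furan-3-yl does not by itself keep a compound at the limit. The value of compound 2 is a limit only, as is that of compound 1: the limit of > 20000 nM in this assay, at which 2 of the 4 values shown sit.

Going by these compounds, whether methylsulfanyl gives a similar step alongside thiophen-3-yl or ethynyl remains open. So does the read-out with methoxy or a primary amine on the same carbon.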